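Methoxy for methylsulfanyl in a small oxazoline series

The compounds below may be only part of what the source reports. "The series", "measured", "known", "first", "only" and "open" are said of these compounds alone.

Compound 1 `Clc1ccc(C2=NC(c3ccccc3)CO2)c(Cl)c1`: 4.4
Compound 2 `CSc1ccccc1C1=NC(c2ccccc2)CO1`: 3.5
Compound 3 `Clc1cccc(Cl)c1C1=NC(c2ccccc2)CO1`: 3.69

Of the compounds shown here, three share a core and have been measured in a physicochemical assay for lipophilicity; on this read-out lower numbers stand for lower lipophilicity and higher numbers for higher lipophilicity. Compound 2 shows the smallest of the three numbers; compound 3 stands within the usual scatter of it, whereas compound 1 stands beyond the scatter above it. The next compound, compound 4 `COc1ccccc1C1=NC(c2ccccc2)CO1`, differs from compound 2 in one place: methoxy in place of methylsulfanyl on an aromatic carbon. Among the measured compounds shown here, no measured pair shows this change, so its size is not known from the data. The step of a number 0.60 log units lower from compound 2 to compound 4 (beyond the scatter) is expected to be downward and somewhat beyond the scatter. For compound 4 the value in this assay is estimated at 2.9, with a range from 2.5 to 3.3.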

Compound 4, partition coefficient: 3.76
For compound 4 the middle estimate is 0.86 log units below the measured one; measured number outside the range, above it.
By their numbers in this assay, from the lowest: compounds 2, 3 and 4 (each within the scatter of the next); then compound 1.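

Read through this assay the swap of methylsulfanyl for methoxy on an aromatic carbon, ortho to a large group, gives a number 0.26 log units higher from compound 2 to compound 4 (within the scatter) and is the first measured case of this change. At this position, then, the two groups cannot be told apart on this read-out, although their heavy-atom and hydrogen-bond counts were already known to match. Nothing measured here offers an explanation for this result. On these data alone, what an amine or a carboxylic acid at this place would do to the number remains open, as does whether this change reads the same at other positions.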